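From compound 3 to compound 4: the dichlorophenyl is rearranged

The source may hold more compounds than are shown below. What is called first, only, known or untested is meant among the compounds shown, and "the series" means these compounds.

Of the compounds shown here, three sharing one core have been measured in a functional assay on SK-BR-3 cells (Homo sapiens) for antiproliferative activity, read by MTT assay, with a stated time of 72 h; a higher number here means a weaker inhibitor, a lower number a stronger inhibitor. Compound 1 `Cc1cc(NCCN(C)C)nc2ccc(NC(=O)c3ccc(Cl)c(Cl)c3)cc12` gives 6670 nM, compound 2 `CCN(CC)CCNc1cc(C)c2cc(NC(=O)c3ccc(Cl)c(Cl)c3)ccc2n1` gives 3710 nM, and compound 3 `CCN1CCN(c2cc(C)c3cc(NC(=O)c4cc(Cl)cc(Cl)c4)ccc3n2)CC1` gives 2660 nM. Compound 3 carries the lowest number of the three; its gap to compound 2 lies within the scatter, while its gap to compound 1 lies beyond it. Among the measured compounds shown here, the only step between two compounds that differ in one place is a 1.8-fold lower number from compound 1 to compound 2 (0.25 log units; within the scatter), a change on the amine side chain, and it stays within the scatter.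

Compound 4 `CCN1CCN(c2cc(C)c3cc(NC(=O)c4ccc(Cl)c(Cl)c4)ccc3n2)CC1` differs from compound 3 by 3,4-dichlorophenyl in place of 3,5-dichlorophenyl on a carbonyl carbon. For the measured compounds named here, no measured step isolates this change: compounds 1 and 2 do carry the 3,4-dichlorophenyl, but they also differ from compound 3 in the amine attached to the core, so their values cannot be read as the effect of moving one chlorine. Going by the values given here, since the one known step, on a remote part of the molecule, stayed within the scatter, the step of a 1.1-fold higher number from compound 3 to compound 4 (0.05 log units; within the scatter) is estimated to stay within the scatter as well, in either direction. Compound 4 is therefore expected at about 3000 nM, with a range from 1000 nM to 9000 nM.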

Compound 4, half-maximal inhibitory concentration: 2160 nM
Compound 4: middle estimate off by 1.4-fold (0.14 log units), on the high side; low and high end bracket the measured number.
By their numbers in this assay, from the lowest: compounds 4, 3, 2 and 1 (each within the scatter of the next, the first and the last beyond it).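

In this assay, the change from 3,5-dichlorophenyl to 3,4-dichlorophenyl on a carbonyl carbon can now be read on its own, as a 1.2-fold lower number from compound 3 to compound 4 (0.09 log units; within the scatter), so these two chlorine patterns are not told apart with 4-ethylpiperazin-1-yl on the shared core. Among the compounds shown here, with 3,4-dichlorophenyl held fixed, the amine can also be compared: 4-ethylpiperazin-1-yl in place of (2-(diethylamino)ethyl)amino gives a 1.7-fold lower number from compound 2 to compound 4 (0.23 log units; within the scatter), while in place of (2-(dimethylamino)ethyl)amino it gives a 3.1-fold lower number from compound 1 to compound 4 (0.49 log units; beyond the scatter), the only one of these steps beyond the scatter, and a modest one. Nothing available offers an explanation for any of these steps.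

On these data alone, how a phenyl with a single chlorine, or a 3,5-dimethoxyphenyl, would read on the same carbonyl carbon remains open. Also open, as far as these compounds go, are whether 4-methylpiperazin-1-yl or morpholin-4-yl on the aromatic carbon would fall with these values, and whether the amine steps would hold with 3,5-dichlorophenyl in place of 3,4-dichlorophenyl.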